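Compound 3: one aryl swap at the assay limit

The source may hold more compounds than are shown below. What is called first, only, known or untested is meant among the compounds shown, and "the series" means these compounds.

In a functional assay on OVCAR-3 cells (Homo sapiens) for antiproliferative activity, read by MTT assay, with a stated time of 24 h (a lower number here means a stronger inhibitor, a higher number a weaker inhibitor), compound 1 (`O=C(NNc1ccc(F)cc1)c1cccc(NS(=O)(=O)c2cnc(O)nc2O)c1`) gives > 20000 nM, which is a limit and not a number. Compound 2 (`Cc1ccc(C(=O)NNC(=O)c2cccc(NS(=O)(=O)c3cnc(O)nc3O)c2)cc1`) gives > 20000 nM, also only a limit. Going by the values given here, that leaves a step that the two limits leave unreadable from compound 1 to compound 2, and the sole evidence is the limit of > 20000 nM in this assay, at which 2 of the 2 values shown sit. Compound 3 (`O=C(NNC(=O)c1cccc(NS(=O)(=O)c2cnc(O)nc2O)c1)c1cccc(Cl)c1`) differs from compound 2 as follows: 3-chlorophenyl in place of 4-methylphenyl on a carbonyl carbon. With no readable step to guide it, no clear shift in either direction is expected in this assay, and the expected step is a step that the limit leaves unreadable from compound 2 to compound 3. For compound 3 the estimated value is 25000 nM, with an expected range of 12000 nM to 50000 nM.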

Compound 3, half-maximal inhibitory concentration: 13500 nM
For compound 3 the middle estimate is 1.9-fold (0.27 log units) above the measured one, and the stated range covers the measured number.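

In this assay, compound 3 is the first compound shown to give a number rather than a limit, so a change on this carbonyl carbon can bring a measurable result. The swap to 3-chlorophenyl gives an at least 1.4-fold lower number from compound 2 to compound 3 (0.17 log units; that floor lies within the scatter), and the change on the amine nitrogen gives an at least 1.4-fold lower number from compound 1 to compound 3 (0.17 log units; that floor lies within the scatter). Both sizes are only floors, and each floor lies within the usual scatter: the limit of > 20000 nM in this assay, at which 2 of the 3 values shown sit.

The compounds shown leave open whether the chlorine itself matters. They also leave open how a different group on this carbonyl carbon, such as an aminomethyl group or a carboxylic acid, would read.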